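Primary amide terminus: cyclobutyl replaces hydroxyethyl

The source may hold more compounds than are shown below. What is called first, only, known or untested is meant among the compounds shown, and "the series" means these compounds.

Measured compounds:
compound 1 `Cn1ncc(Cl)c1-c1cc(C(=O)N[C@@H]2CN[C@H](CC(N)=O)C[C@H]2c2ccc(Cl)c(Cl)c2)oc1Cl`, 3.24 nM
compound 2 `Cn1ncc(Cl)c1-c1cc(C(=O)N[C@@H]2CN[C@H](CCN3CCCC3)C[C@H]2c2ccc(Cl)c(Cl)c2)oc1Cl`, 6.41 nM
compound 3 `Cn1ncc(Cl)c1-c1cc(C(=O)N[C@@H]2CN[C@H](CC(=O)NCCO)C[C@H]2c2ccc(Cl)c(Cl)c2)oc1Cl`, 1.41 nM

All three values are in an assay for inhibition of RAC-alpha serine/threonine-protein kinase (Homo sapiens), read by HTRF, with a stated time of 1 h; a higher number here means a weaker inhibitor, a lower number a stronger inhibitor. On these numbers compound 3 gives the lowest figure: it stands a 2.3-fold lower number from compound 1 to compound 3 (0.36 log units; beyond the scatter) and a 4.5-fold lower number from compound 2 to compound 3 (0.66 log units; beyond the scatter). The remaining measured pair shows a 2.0-fold higher number from compound 1 to compound 2 (0.30 log units; within the scatter).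

Compound 4 `Cn1ncc(Cl)c1-c1cc(C(=O)N[C@@H]2CN[C@H](CC(=O)NC3CCC3)C[C@H]2c2ccc(Cl)c(Cl)c2)oc1Cl` differs from compound 3 by cyclobutyl in place of 2-hydroxyethyl on an amide-type nitrogen. Within the data shown here, the nearest precedent is the amide-nitrogen change a 2.3-fold lower number from compound 1 to compound 3 (0.36 log units; beyond the scatter); the change to compound 4 sits on the same nitrogen but removes what compound 3 added, so no step beyond the scatter is expected in this assay. For compound 4 the expected step is a 1.8-fold higher number from compound 3 to compound 4 (0.25 log units; within the scatter), with an estimate of 2.5 nM (range 0.8 nM to 8 nM).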

Compound 4, half-maximal inhibitory concentration: 7.98 nM
For compound 4 the middle estimate is 3.2-fold (0.50 log units) below the measured one, and the stated range covers the measured number.
By their numbers in this assay, from the lowest: compound 3; then compounds 1, 2 and 4 (each within the scatter of the next, the first and the last beyond it).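

In this assay the amide nitrogen proves sensitive to its substituent: cyclobutyl in place of 2-hydroxyethyl gives a 5.7-fold higher number from compound 3 to compound 4 (0.75 log units; beyond the scatter), while cyclobutyl in place of hydrogen gives a 2.5-fold higher number from compound 1 to compound 4 (0.39 log units; beyond the scatter), so substitution here does not act in one direction. Cyclobutylcarbamoyl in place of (pyrrolidin-1-yl)methyl gives a 1.2-fold higher number from compound 2 to compound 4 (0.10 log units; within the scatter), leaving those two side chains unseparated. No available evidence explains these steps.

Still open, on these data alone, is whether an ethyl or 2-methoxyethyl group on this nitrogen would track compound 3 or compound 4, separating the hydroxyl from the carbon framework.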